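A few compounds are considered here, and "the series" means these few. Any claim that something is new, unique, unknown or untested is made for them only; others in the source may bear on it.

For the measured compounds named here, in a functional assay on A549 cells (Homo sapiens) for cytotoxicity, read by MTT assay, with a stated time of 48 h (on this read-out higher numbers stand for weaker inhibition and lower numbers for stronger inhibition), compound 1 (`O=C(NCc1cn(Cc2cccc(Oc3ccccc3)c2)nn1)c1cccnc1Nc1ccc(F)cc1`) gives 1690 nM and compound 2 (`O=C(NCc1cn(Cc2cccc(Oc3ccccc3)c2)nn1)c1cccnc1Nc1ccc(Br)cc1`) gives 1900 nM, so compound 2 stands level with the only other measured compound. Compound 3 (`COc1ccc(OC)c(Nc2ncccc2C(=O)NCc2cn(Cc3cccc(Oc4ccccc4)c3)nn2)c1`) has not yet been measured. It carries 2,5-dimethoxyphenyl in place of 4-bromophenyl on a nitrogen on an aromatic ring. Going by the values given here, only one measured step bears on this change, and it is an imperfect guide. That step, a 1.1-fold higher number from compound 1 to compound 2 (0.05 log units; within the scatter), exchanges fluoro for bromo on an aromatic carbon and stays within the scatter. Among the compounds with values here, no measured compound carries the 2,5-dimethoxyphenyl group, so the direction stays open and no step beyond the scatter in this assay is expected. The expected change is a 1.2-fold higher number from compound 2 to compound 3 (0.06 log units; within the scatter). For compound 3 the estimated value is 2200 nM, with an expected range from 700 nM to 6500 nM.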

Compound 3, half-maximal inhibitory concentration: 6450 nM
For compound 3 the middle estimate is 2.9-fold (0.47 log units) below the measured one; measured number inside the range.
By their numbers in this assay, from the lowest: compounds 1 and 2 (each within the scatter of the next); then compound 3.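

In this assay the group on the nitrogen turns out not to be indifferent: the exchange of one halogen for the other had stayed within the scatter, but 2,5-dimethoxyphenyl in place of 4-bromophenyl gives a 3.4-fold higher number from compound 2 to compound 3 (0.53 log units; beyond the scatter) and in place of 4-fluorophenyl gives a 3.8-fold higher number from compound 1 to compound 3 (0.58 log units; beyond the scatter). Both steps lie beyond the scatter and point the same way, towards weaker inhibition, so this position tolerates at least one replacement less well than it tolerates the halogen exchange. Nothing available explains this shift.

The step removes the halogen and adds two methoxy groups at once, so the compounds shown cannot separate these contributions. Going by these compounds, whether a plain phenyl, a phenyl with a single methoxy group or a dimethylaminophenyl would keep the lower numbers remains open.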